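From Methyl Ester to Branched Acid: Thromboxane Synthase Inhibition

A few compounds are considered here, and "the series" means these few. Any claim that something is new, unique, unknown or untested is made for them only; others in the source may bear on it.

Measured so far:
Compound 1 `COC(=O)CCCC/C=C(\c1ccccc1)c1cccnc1` gives 100 nM in an assay (Equus caballus) for inhibition of Thromboxane-A synthase (Homo sapiens), using microsomes; on this read-out lower numbers stand for stronger inhibition and higher numbers for weaker inhibition.
Compound 2 `O=C(O)CCCC/C=C\c1cccnc1` gives 250 nM in this assay.
Compound 3 `O=C(O)CCCC/C=C(/c1ccccc1)c1ccccn1` gives only a limit of the assay, > 100000 nM, in this assay.

Compound 1 thus holds the lowest of the two numbers measured; compound 2 sits above it, beyond the scatter, and compound 3 reaches only a limit (the limit of > 100000 nM in this assay, at which 1 of the 3 values shown sits). Compound 4 `CC(C)(CCCC/C=C(\c1ccccc1)c1cccnc1)C(=O)O` differs from compound 1 in one place: 1-carboxy-1-methylethyl in place of methoxycarbonyl on a saturated chain carbon, four bonds along the chain from a double-bonded chain carbon. Among the compounds with values here, no measured pair shows this change, so its size is an expectation only. Compound 4 is estimated at 60 nM, with a range from 15 nM to 300 nM, an expected step of a 1.7-fold lower number from compound 1 to compound 4 (0.22 log units; within the scatter) that may stay within the scatter.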

Compound 4, half-maximal inhibitory concentration: 45 nM
Compound 4: middle estimate off by 1.3-fold (0.12 log units), on the high side; the range from low to high includes it.
By their numbers in this assay, from the lowest: compound 4; then compound 1; then compound 2. At a limit, above all of these: compound 3.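

Exchanging methoxycarbonyl for 1-carboxy-1-methylethyl on a saturated chain carbon, four bonds along the chain from a double-bonded chain carbon, gives in this assay a 2.2-fold lower number from compound 1 to compound 4 (0.35 log units; beyond the scatter). Within the data shown here, this position therefore accepts the larger, branched acid group without any loss of inhibition, a point the earlier compounds, with no single-place step among them, could not show. Nothing measured here explains this step. The compounds shown leave open how an unbranched carboxylic acid on the core of compound 1 would read, and so whether the acid or its branching carries the step. Going by these compounds, a longer chain ending in 1-carboxy-1-methylethyl also remains open.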